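A few compounds are considered here, and "the series" means these few. Any claim that something is new, unique, unknown or untested is made for them only; others in the source may bear on it.

Values in a functional assay on DU-145 cells (Homo sapiens) for inhibition, read by trypan blue exclusion, with a stated time of 96 h; on this read-out higher numbers stand for weaker inhibition of growth and lower numbers for stronger inhibition of growth
- compound 1 `O=C(/C(=C\c1c[nH]c2ccc(Cl)cc12)SCc1ccc(F)cc1)c1ccc(Br)cc1` (1000 nM)
- compound 2 `Cc1ccc(S/C(=C/c2c[nH]c3ccc(Cl)cc23)C(=O)c2ccc(Br)cc2)cc1` (1000 nM)

Going by the values given here, compound 1 stands level with compound 2, its only measured neighbour. The move to compound 3 `COc1ccc(/C=C(/SCc2ccc(F)cc2)C(=O)c2ccc(Br)cc2)cc1O` is 3-hydroxy-4-methoxyphenyl in place of 5-chloro-1H-indol-3-yl on a double-bonded chain carbon bound to a double-bonded chain carbon and puts 3-hydroxy-4-methoxyphenyl in place of 5-chloro-1H-indol-3-yl on a double-bonded chain carbon bound to a double-bonded chain carbon. Among the compounds with values here, the one measured step, no change at the digits printed from compound 1 to compound 2 (within the scatter) for 4-methylphenyl in place of 4-fluorobenzyl on a sulfur, lies within the scatter. That step concerns another place in the molecule, so it bears on this change only weakly. Within the data shown here, no measured compound varies the 5-chloro-1H-indol-3-yl, and the data give no direction. In this assay no shift beyond the scatter is therefore expected, though with wide uncertainty. The estimated step is no change at the digits printed from compound 1 to compound 3 (within the scatter) and no more than a default. For compound 3 the expected value is 1000 nM (estimated range 200 nM to 5000 nM).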

Compound 3, concentration for 50% growth inhibition: 1000 nM
Compound 3: the middle estimate sits on the measured number at the digits printed, within the range that was stated.
By their numbers in this assay, from the lowest: compounds 1, 2 and 3 (each within the scatter of the next).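

In this assay, going by these compounds alone, putting 3-hydroxy-4-methoxyphenyl in place of 5-chloro-1H-indol-3-yl on a double-bonded chain carbon bound to a double-bonded chain carbon gives no change at the digits printed from compound 1 to compound 3 (within the scatter), the first reading at this place. With the 4-fluorobenzyl on sulfur held constant, the value therefore survives the loss of the five-membered aromatic ring, its nitrogen and the chlorine, and the entry of two oxygens. Nothing at hand accounts for the two groups reading alike.

Open, from the compounds shown here alone, is whether any group at this place moves the value beyond the scatter, for example an aminophenyl or a carboxyphenyl ring. Also open, going by these compounds, is whether 4-methylphenyl on a sulfur reads the same alongside 3-hydroxy-4-methoxyphenyl as it does alongside 5-chloro-1H-indol-3-yl.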